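The source may hold more compounds than are shown below. What is called first, only, known or untested is meant among the compounds shown, and "the series" means these compounds.

Two compounds of the series have so far been run in an ADME assay on cells (Homo sapiens) for cytotoxicity, read by polymerase chain reaction, with a stated time of 3 days; on this read-out higher numbers stand for lower toxicity in this test and lower numbers for higher toxicity in this test. Compound 1 `Nc1nc(Cl)c(-c2nc3ccc(F)cc3s2)c(N[C@@H]2C[C@H](CO)[C@@H](O)[C@H]2O)n1` returns only a limit, > 25000 nM. Compound 2 `CCCNc1nc(C)c(-c2nc3ccccc3s2)c(N[C@@H]2C[C@H](CO)[C@@H](O)[C@H]2O)n1` likewise returns only a limit, > 25000 nM. Both readings sit at the limit of > 25000 nM in this assay, at which 2 of the 2 values shown sit, so compound 2 stands at the limit together with compound 1 and no number separates the two. Compound 3 `Cc1nc(NCc2nccs2)nc(N[C@@H]2C[C@H](CO)[C@@H](O)[C@H]2O)c1-c1nc2ccccc2s1` differs from compound 2 by 1,3-thiazol-2-yl in place of ethyl on a saturated chain carbon bound to a nitrogen on an aromatic ring. Going by the values given here, no measured step is available to size this change; the step that the limit leaves unreadable from compound 2 to compound 3 is expected to be none beyond the scatter. Compound 3 is estimated at about 30000 nM, within 15000 nM to 60000 nM, most likely again reported as a limit only.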

Compound 3, half-maximal cytotoxic concentration: 23000 nM
Beside the measured number, compound 3's estimate is 1.3-fold (0.12 log units) above it, within the range that was stated.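

In this assay, going by these compounds alone, 1,3-thiazol-2-yl in place of ethyl on a saturated chain carbon bound to a nitrogen on an aromatic ring gives an at least 1.0-fold lower number from compound 2 to compound 3 (0.03 log units; that floor lies within the scatter) as the only reading of this change. Within the data shown here, compound 3 carries the first number at this position that is not a limit, whereas the earlier compounds gave only this: the limit of > 25000 nM in this assay, at which 2 of the 3 values shown sit.
On these data alone, the step is a floor, so its true size remains open. As far as these compounds go, how a longer chain or a carboxylic acid at this place would read in this assay also remains open.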